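Working notes on the trifluoromethyl-to-hydrogen step toward compound 4

A few compounds are considered here, and "the series" means these few. Any claim that something is new, unique, unknown or untested is made for them only; others in the source may bear on it.

Three compounds carry numbers in an assay on isolated protein for inhibition of aldehyde dehydrogenase 1A1 (Homo sapiens), read by spectrophotometry, tested at 10 uM; a lower number here means less inhibition, a higher number more inhibition at the concentration tested (going by the name of the read-out). Compound 1 `Cc1cccc(Cn2c(OC3CCN(C(=O)c4ccco4)CC3)nc3ccccc32)c1` gives 68.3% in this assay. Compound 2 `Cc1cccc(Cn2c(CN3CCN(C(=O)c4cccnc4)CC3)nc3ccccc32)c1` gives 24.5% in this assay. Compound 3 `O=C(C1CC1)N1CCN(Cc2nc3ccccc3n2Cc2ccccc2C(F)(F)F)CC1` gives 56.3% in this assay. On these three numbers compound 3 stands second highest: compound 1 lies above it by a gap beyond the scatter, and compound 2 lies below it by a larger gap, also beyond the scatter. Within the data shown here, compounds 1 and 2 each differ from compound 3 in more than one place, so no single step between measured compounds can be read off, and nothing among them isolates what the trifluoromethyl group contributes.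

Compound 4 `O=C(C1CC1)N1CCN(Cc2nc3ccccc3n2Cc2ccccc2)CC1` has no number yet in this assay. Relative to compound 3 the change is hydrogen in place of trifluoromethyl on an aromatic carbon; cut one bond further out it reads 2-(trifluoromethyl)phenyl to phenyl. Among the measured compounds shown here, no measured step of this kind exists in the set, so the expectation for compound 4 rests on compound 3 and its value of 56.3% alone. The step is expected to be a number 11.3 percentage points lower from compound 3 to compound 4 (beyond the scatter), a modest fall that may well sit within the scatter. Compound 4 is therefore expected to give 45% in this assay, within a range of 25% to 65%.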

Compound 4, a percentage reported as inhibition, at one concentration (the size of the read-out at that concentration, not a potency): 23.9%
Estimate against measurement, compound 4: 21.1 percentage points above; the whole stated range lies above it.
By their numbers in this assay, from the lowest: compounds 4 and 2 (each within the scatter of the next); then compound 3; then compound 1.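

Among these compounds, with the rest of the structure unchanged, hydrogen in place of trifluoromethyl on an aromatic carbon ortho to a large group gives a number 32.4 percentage points lower from compound 3 to compound 4 (beyond the scatter) in this assay, and this is the first comparison that differs in one place only. The inhibition read at the concentration tested is therefore sensitive to what stands at this position, which compound 1 and compound 2 could not show, as each differs from compound 3 in more than one place. No measurement on hand bears on why the number falls with this change.

Going by these compounds, whether a methyl, a chlorine or a methoxy on this same carbon would hold the number near that of compound 3 or let it drop toward that of compound 4 stays open. Also open, on these data alone, is whether the change keeps its size when the cyclopropyl carbonyl of compound 3 gives way to an acetyl group or a longer chain.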